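A few compounds are considered here, and "the series" means these few. Any claim that something is new, unique, unknown or untested is made for them only; others in the source may bear on it.

Compound 1 `COc1cc2c(Oc3ccc(NC(=O)c4nn(-c5cccc(F)c5)c(=O)cc4C)cc3F)ccnc2cc1OCCCN1CCC(C)CC1` — 250 nM
Compound 2 `COc1cc2c(Oc3ccc(NC(=O)c4nn(-c5ccc(Cl)cc5)c(=O)cc4C)cc3F)ccnc2cc1OCCCN1CCC(C)CC1` — 370 nM

In a functional assay on NCI-H460 cells (Homo sapiens) for inhibition, read by MTT assay, with a stated time of 72 h (on this read-out lower numbers stand for stronger inhibition and higher numbers for weaker inhibition), compound 2 has the highest of the two numbers, with compound 1 nearest, a 1.5-fold higher number from compound 1 to compound 2 (0.17 log units; within the scatter). Compound 3 `COc1cc2c(Oc3ccc(NC(=O)c4nn(-c5ccc(Cl)cc5Cl)c(=O)cc4C)cc3F)ccnc2cc1OCCCN1CCC(C)CC1` differs from compound 2 by chloro in place of hydrogen on an aromatic carbon. Within the data shown here, the only measured step, the one from compound 1 to compound 2, changed the same aryl group on the shared core and stayed within the scatter, so the added chloro is expected to give at most a modest change in this assay, with no clear direction. Compound 3 is therefore estimated at 400 nM, range 150 nM to 1100 nM, meaning an expected 1.1-fold higher number from compound 2 to compound 3 (0.03 log units; within the scatter).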

Compound 3, half-maximal inhibitory concentration: 250 nM
For compound 3 the middle estimate is 1.6-fold (0.20 log units) above the measured one; the measured number falls inside the stated range.
By their numbers in this assay, from the lowest: compounds 1, 3 and 2 (each within the scatter of the next).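

A second halogen on this ring is now seen at the carbon ortho to a large group: in this assay the chloro gives a 1.5-fold lower number from compound 2 to compound 3 (0.17 log units; within the scatter) and so does not move the number beyond the scatter. The full change to 2,4-dichlorophenyl gives no change at the digits printed from compound 1 to compound 3 (within the scatter) and thus also stays within it, so all three aryl groups on the aromatic nitrogen read alike here. No supporting data bear on this result.

As far as these compounds go, whether this position would stay as undemanding with a methoxy group, an amine or a carboxylic acid in place of the chloro remains open.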